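A thiourea-to-urea swap on a benzyloxy-biphenyl sulfonamide

This account rests on a few compounds, and the source may have more. Where it says the series, first, only, none or still open, it means among the compounds named here.

Compound 3 `O=S(=O)(NCCNC(=S)Nc1ccc(Cl)cc1)c1ccc(-c2ccccc2OCc2ccccc2)s1` reaches only a limit in a functional assay on HL-60 cells (Homo sapiens) for inhibition, read by CCK-8 assay, with a stated time of 48 h; a lower number here means a stronger inhibitor, a higher number a weaker inhibitor: compound 3 gives > 50000 nM, a limit of the assay rather than a number. Compound 2 `O=S(=O)(NCCNC(=S)Nc1cccc(Cl)c1)c1ccc(-c2ccccc2OCc2ccccc2)s1` likewise gives > 50000 nM, a limit. The step that the two limits leave unreadable from compound 2 to compound 3 therefore cannot be read, because of the limit of > 50000 nM in this assay, at which 2 of the 3 values shown sit. Within the data shown here, compound 1 `O=C(NCCNS(=O)(=O)c1ccc(-c2ccccc2Oc2ccc(O)c(O)c2)s1)Nc1cc(Cl)cc(Cl)c1`, which carries the (3,5-dichlorophenyl)carbamoyl group together with a catechol instead of the benzyloxy group, gives 10400 nM in this assay, and is the only compound here with a number.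

Compound 4 `O=C(NCCNS(=O)(=O)c1ccc(-c2ccccc2OCc2ccccc2)s1)Nc1cc(Cl)cc(Cl)c1` differs from compound 3 by a group of 11 heavy atoms (7 carbon, 1 nitrogen, 1 oxygen, 2 chlorine; one six-membered aromatic ring of carbon only) in place of a group of 10 heavy atoms (7 carbon, 1 nitrogen, 1 sulfur, 1 chlorine; one six-membered aromatic ring of carbon only), on an amine nitrogen. Among the measured compounds shown here, no measured step bears on this change; the only readable value, that of compound 1, shares the entering group but not the rest of the structure. Compound 4 is therefore expected to remain weak, with a good chance of another limit. The estimate for compound 4 in this assay is 30000 nM, between 8000 nM and 100000 nM, which means an expected step of an at least 1.6-fold lower number from compound 3 to compound 4 (0.22 log units; that floor lies within the scatter).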

Compound 4, half-maximal inhibitory concentration: 11700 nM
Beside the measured number, compound 4's estimate is 2.6-fold (0.41 log units) above it; the measured number falls inside the stated range.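

In this assay, among these compounds, the (3,5-dichlorophenyl)carbamoyl group on the amine nitrogen gives an at least 4.2-fold lower number from compound 3 to compound 4 (0.63 log units; beyond the scatter) and an at least 4.2-fold lower number from compound 2 to compound 4 (0.63 log units; beyond the scatter) on the benzyloxy-bearing core, the first readable numbers for that core. With the carbamoyl group held constant, benzyl in place of 3,4-dihydroxyphenyl on an oxygen on an aromatic ring gives a 1.1-fold higher number from compound 1 to compound 4 (0.05 log units; within the scatter) and so shows that the 3,4-dihydroxyphenyl group is not required for a readable number here. The two steps from compound 2 and compound 3 give only a floor and not a size because those compounds stand at a limit: the limit of > 50000 nM in this assay, at which 2 of the 4 values shown sit.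

Oxygen replaces sulfur and the chlorine count changes in the same step, so the contribution of each remains unresolved. From the compounds shown here alone, how an amine or a carboxylic acid on the phenyl ring, or a longer chain on the amine nitrogen, would read also remains open.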